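Fluoro to hydrogen on the pyridyl ring: expected effect

A few compounds are considered here, and "the series" means these few. Any claim that something is new, unique, unknown or untested is made for them only; others in the source may bear on it.

Three amidrazone thiosemicarbazides have been measured in a functional assay on HeLa cells (Homo sapiens) for cytotoxicity, read by MTT assay, with a stated time of 72 h, tested at 100 uM; a lower number here means less inhibition of growth, a higher number more inhibition of growth at the concentration tested. Compound 1 `Cc1cccc(/C(N)=N/NC(=S)N2CCCCC2)n1` gives 85.4%. Compound 2 `N/C(=N\NC(=S)N1CCN(c2ccccn2)CC1)c1ccc(F)cn1` gives 83%. Compound 3 `Cc1ccnc(/C(N)=N/NC(=S)N2CCOCC2)c1` gives 82.7%. The three numbers sit close together: compound 2 lies level with compound 3 and with compound 1, and each gap between any two of them is within the usual scatter, so no order among them can be drawn from this assay.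

Compound 4 `N/C(=N\NC(=S)N1CCN(c2ccccn2)CC1)c1ccccn1` has not yet been measured. It differs from compound 2 in one place: hydrogen in place of fluoro on an aromatic carbon. The change removes one heavy atom from the six-membered aromatic ring with one nitrogen and replaces it with a hydrogen atom; the rest of the structure is kept.

Within the data shown here, no pair of measured compounds shows this change, so nothing speaks for a move beyond the scatter. The step of a number 1 percentage points lower from compound 2 to compound 4 (within the scatter) is expected to be small. Compound 4 is therefore estimated at 82%, with a range from 70% to 92%.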

Compound 4, percent growth inhibition at one concentration: 85.6%
Compound 4: middle estimate off by 3.6 percentage points, on the low side; measured number inside the range.
By their numbers in this assay, from the lowest: compounds 3, 2, 1 and 4 (each within the scatter of the next).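

In this assay, among these compounds, hydrogen in place of fluoro gives the first one-place comparison, with a number 2.6 percentage points higher from compound 2 to compound 4 (within the scatter) as its step. At this aromatic carbon, two atoms from the ring nitrogen and para to a large group, the fluoro is therefore not required for growth inhibition at the concentration tested, since 5-fluoropyridin-2-yl and pyridin-2-yl read alike here. No measurement on hand bears on why the two compounds read alike.

A read-out at one concentration leaves open whether compound 2 and compound 4 would separate at lower concentrations. Also open, from the compounds shown here alone, is whether another group at this position, such as methoxy, an amine or a carboxylic acid, would move the number beyond the scatter.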